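Trading Dichlorophenyl for a Methylpyridine on the Amide

The compounds below may be only part of what the source reports. "The series", "measured", "known", "first", "only" and "open" are said of these compounds alone.

Compound 1 `COc1ccc(C(=O)Nc2cccc(Cl)c2Cl)cc1OC1CCCC1` was tested in an assay on isolated protein for inhibition of phosphodiesterase 4A (Sus scrofa); a lower number here means a stronger inhibitor, a higher number a weaker inhibitor. In this assay compound 1 gives only a limit, > 200000 nM, as shown by the limit of > 200000 nM in this assay, at which 1 of the 2 values shown sits. Compound 2 `COc1ccc(/C(S)=N/c2ccccc2Cl)cc1OC1CCCC1`, a related thioamide, gives 200 nM in this assay. Compound 3 `COc1ccc(C(=O)Nc2ncccc2C)cc1OC1CCCC1` has not yet been measured. It differs from compound 1 in one place: 3-methylpyridin-2-yl in place of 2,3-dichlorophenyl on an amide-type nitrogen. Within the data shown here, no measured step of this kind exists here, so the expectation is an uncertain but large move toward stronger inhibition, the step of an at least 40-fold lower number from compound 1 to compound 3 (1.60 log units; beyond the scatter) being estimated. Compound 3 is expected to come in near 5000 nM, plausibly between 500 nM and 100000 nM.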

Compound 3, half-maximal inhibitory concentration: 3100 nM
Estimate against measurement, compound 3: 1.6-fold (0.21 log units) above; measured number inside the range.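

On the amide-type nitrogen, 3-methylpyridin-2-yl in place of 2,3-dichlorophenyl gives an at least 64-fold lower number from compound 1 to compound 3 (1.80 log units; beyond the scatter) in this assay, so the group at this position can strongly change inhibition. That step is a lower bound rather than an exact size, because compound 1 gives only a limit: the limit of > 200000 nM in this assay, at which 1 of the 3 values shown sits.

From the compounds shown here alone, the ring nitrogen, the methyl and the loss of both chlorines all arrive in one change, so their separate contributions remain unknown. Also open, going by these compounds, is how a plain pyridin-2-yl, without the methyl, would compare on the same amide-type nitrogen.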